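Bromo Addition on Two Anilide Cores Near the Limit

The source may report more compounds than this note shows. Statements on the series, on what has been measured and on what is new or still open speak of the compounds shown alone.

Compound 1 `COc1c(Br)cc(Br)cc1C(=O)Nc1ccccc1` and compound 2 `COc1c(Br)cccc1C(=O)Nc1ccccc1` share one core. Compound 3 `O=C(Nc1ccc(Sc2nc3ccccc3s2)cc1)c1ccccc1O` is built on another core, and the difference between the two cores is not broken down here. Compound 4 `O=C(Nc1ccc(Sc2nc3ccccc3s2)cc1)c1cccc(Br)c1O` carries one further substituent on the core of compound 3 and has not yet been measured.

In an assay for inhibition of HSP60/HSP10 (Homo sapiens), with a stated time of 60 min (a lower number here means a stronger inhibitor, a higher number a weaker inhibitor), compound 1 gives > 100000 nM, which is a limit of the assay and not a number. Compound 2 gives > 100000 nM, again a limit. Compound 3 gives > 100000 nM, also a limit. All three measured values share (the limit of > 100000 nM in this assay, at which 3 of the 3 values shown sit).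

The change from compound 2 to compound 1 is bromo in place of hydrogen on an aromatic carbon and gives a step that the two limits leave unreadable from compound 2 to compound 1. The change from compound 3 to compound 4 is bromo in place of hydrogen on an aromatic carbon. The surroundings of the place differ: in compound 1 the entering bromo sits meta to a bromo group, meta to a group of 9 heavy atoms and para to a methoxy group, whereas in compound 4 it sits ortho to a hydroxy group and meta to a large group. It is therefore the same kind of change, not the same.

The expected step is a number no higher from compound 3 to compound 4 (the limit leaves the size open), because the earlier step that the two limits leave unreadable from compound 2 to compound 1 stayed unreadable between two limits. Compound 3 sits at the limit > 100000 nM. Compound 4 is expected at about 100000 nM, within 30000 nM to 300000 nM, and most probably again only as a limit.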

Compound 4, half-maximal inhibitory concentration: 26000 nM
For compound 4 the middle estimate is 3.8-fold (0.59 log units) above the measured one, outside the stated range (below it).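

In this assay, among these compounds, bromo in place of hydrogen on an aromatic carbon of the core of compound 3, ortho to a hydroxy group, gives an at least 3.8-fold lower number from compound 3 to compound 4 (0.58 log units; beyond the scatter) and is the only readable instance of this change. The same kind of change on the core of compound 2 gives a step that cannot be read, because both compounds of that pair stand at a limit: the limit of > 100000 nM in this assay, at which 3 of the 4 values shown sit. On these data alone, the result therefore shows that this change can lower the number on one core, but it does not show that the effect carries from one core to the other, and the entering bromo has different surroundings in compound 1 and compound 4, while the full size of the step stays open with compound 3 at a limit.

The compounds shown leave open whether chloro, methyl or an amine at the same place on the core of compound 3 would give a step of like direction, and whether a carboxylic acid there would do so. They also leave open whether the step on this core holds once the hydroxy group is replaced by a methoxy group.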